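Amide nitrogen substituent swap in the vinyl-dihydrofuran acid series

This account rests on a few compounds, and the source may have more. Where it says the series, first, only, none or still open, it means among the compounds named here.

Compound 2 `C=CC1=C(C(=O)Nc2ccc(C)cc2)C(c2ccc(F)cc2)OC1` is the amide of compound 1 `C=CC1=C(C(=O)O)C(c2ccc(F)cc2)OC1`. In a functional assay on SW480 cells (Homo sapiens) for cytotoxicity, read by MTT assay, with a stated time of 24 h (on this read-out lower numbers stand for stronger inhibition and higher numbers for weaker inhibition), compound 1 gives > 100000 nM, which is a limit of the measurement and not a number. In this assay compound 2 gives > 100000 nM, again a limit rather than a number. The step that the two limits leave unreadable from compound 1 to compound 2 therefore cannot be read; both values sit at the limit of > 100000 nM in this assay, at which 2 of the 2 values shown sit. Compound 3 `C=CC1=C(C(=O)NCCCCC)C(c2ccc(F)cc2)OC1` differs from compound 2 by pentyl in place of 4-methylphenyl on an amide-type nitrogen. No measured step touches the amide nitrogen substituent, and the only step shown is itself unreadable, so nothing among the measured compounds speaks to the direction or size of this change. With compound 2 at the limit, the expectation for compound 3 is that it also reaches no measurable inhibition, an estimated step that the limit leaves unreadable from compound 2 to compound 3. Compound 3 is thus expected at 150000 nM, within 40000 nM to 600000 nM.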

Compound 3, half-maximal inhibitory concentration: > 100000 nM
Compound 3: no number, only a limit; the forecaster's own chance of this, stated with the estimate: 80%; the middle value lies beyond the limit too.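

Among these compounds, no step from compound 1 or compound 2 to compound 3 can be read in this assay, as the values are limits and not numbers: the limit of > 100000 nM in this assay, at which 3 of the 3 values shown sit. The compounds shown leave open whether any substituent on the amide nitrogen of the shared core gives measurable inhibition, and how the acid and the two amides rank.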